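The compounds below may be only part of what the source reports. "The series", "measured", "known", "first", "only" and "open" are said of these compounds alone.

Compound 1 `O=C(Nc1ccc(Sc2nc3ccccc3s2)c(Cl)c1)c1cc(Br)cc(Br)c1` and compound 2 `O=C(Nc1cccc(Cl)c1)c1cccc(Br)c1` are both amides of a chlorinated aniline, but the difference between their two cores is not broken down here. In an assay for inhibition of HSP60/HSP10 (Homo sapiens), with a stated time of 60 min (on this read-out lower numbers stand for stronger inhibition and higher numbers for weaker inhibition), compound 1 gives > 100000 nM, which is a limit of the assay rather than a number. Compound 2 likewise reaches only a limit of the assay, > 100000 nM. Compound 3 `O=C(Nc1ccc(Sc2nc3ccccc3s2)c(Cl)c1)c1cc(Br)cc(Br)c1O` carries hydroxy in place of hydrogen on an aromatic carbon, and in this assay compound 3 gives 4200 nM. The resulting step, an at least 23-fold lower number from compound 1 to compound 3 (1.37 log units; beyond the scatter), begins at the limit of > 100000 nM in this assay, at which 2 of the 3 values shown sit. Compound 4 `O=C(Nc1cccc(Cl)c1)c1cccc(Br)c1O` is to be measured in this assay; it bears hydroxy in place of hydrogen on an aromatic carbon. For the measured compounds named here, this is the same kind of change as the one leading to compound 3, though the place in compound 3 is also para to a bromo group, which the place in compound 4 is not. For compound 4 the step is expected to be an at least 2.0-fold lower number from compound 2 to compound 4 (0.30 log units; that floor lies within the scatter). That expectation rests on the gain seen in an at least 23-fold lower number from compound 1 to compound 3 (1.37 log units; beyond the scatter) and on compound 2 sitting at the limit of > 100000 nM in this assay, at which 2 of the 3 values shown sit. Compound 4 is therefore estimated at 50000 nM, within a range from 5000 nM to 300000 nM.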

Compound 4, half-maximal inhibitory concentration: > 100000 nM
Compound 4: no number, only a limit (the forecaster's own chance of this, stated with the estimate: 55%); middle value at least 2.0-fold (0.30 log units) from the limit.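

In this assay compound 4 gives > 100000 nM, which is a limit of the assay and not a number. No step from compound 2 to compound 4 can be read, because both compounds sit at the same limit: the limit of > 100000 nM in this assay, at which 3 of the 4 values shown sit.

The compounds shown leave open whether hydroxy in place of hydrogen changes inhibition at all on the core of compound 2.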